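This account rests on a few compounds, and the source may have more. Where it says the series, first, only, none or still open, it means among the compounds named here.

Compound 3 `Cc1noc(C)c1C(c1ccccc1)N1CCN(c2ncnc3c2cnn3-c2ccccc2)CC1` carries a 3,5-dimethyl-1,2-oxazol-4-yl group on a saturated chain carbon bound to an amine nitrogen in a ring and an aromatic carbon. In a functional assay on cells (Rhabdomyosarcoma cell, Homo sapiens) for cytotoxicity (a lower number here means a stronger inhibitor, a higher number a weaker inhibitor), compound 3 gives only a limit, > 25000 nM, not a number. Compound 1 `Cc1ccccc1C(c1ccccc1)N1CCN(c2ncnc3c2cnn3-c2ccccc2)CC1` likewise shows only a limit in this assay, > 25000 nM. Compound 2 `Brc1ccc(C(c2ccccc2)N2CCN(c3ncnc4c3cnn4-c3ccccc3)CC2)cc1` also reaches only a limit, > 25000 nM. The steps among these three, a step that the two limits leave unreadable from compound 1 to compound 2, a step that the two limits leave unreadable from compound 1 to compound 3 and a step that the two limits leave unreadable from compound 2 to compound 3, therefore cannot be sized.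

Compound 4 `c1ccc(C(c2ccco2)N2CCN(c3ncnc4c3cnn4-c3ccccc3)CC2)cc1` differs from compound 3 by furan-2-yl in place of 3,5-dimethyl-1,2-oxazol-4-yl on a saturated chain carbon bound to an amine nitrogen in a ring and an aromatic carbon. Within the data shown here, no measured step gives a readable direction for this exchange, because every group tried in that place sits at the same ceiling (the limit of > 25000 nM in this assay, at which 3 of the 3 values shown sit). The expected step in this assay is a step that the limit leaves unreadable from compound 3 to compound 4, with the result most likely again reported only as a limit. Compound 4 is estimated at 30000 nM, in a range from 10000 nM to 100000 nM.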

Compound 4, half-maximal inhibitory concentration: > 25000 nM
Compound 4 gave a limit, no number; the forecaster's own chance of this, stated with the estimate: 85%; the middle value is on the limit's open side.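

Compound 4 gives only a limit in this assay, so its steps from compound 1, compound 2 and compound 3 cannot be read: the limit of > 25000 nM in this assay, at which 4 of the 4 values shown sit.

The compounds shown leave open how these four groups rank in this assay, and whether any group in this place would give a measured number.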